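The compounds below may be only part of what the source reports. "The series", "measured", "known", "first", "only" and "open" are said of these compounds alone.

Measured compounds and their results:

Compound 1, `CCCSC[C@H](NC(C)=O)C(=O)CCl`: 8000 nM
Compound 2, `CCCCSC[C@H](NC(C)=O)C(=O)CCl`: 5600 nM
Compound 3, `CCCCCCCCCCCCCCSC[C@H](NC(C)=O)C(=O)CCl`: 8800 nM

All three were tested in a functional assay on MOLT-3 cells (Homo sapiens); a lower number here means a stronger inhibitor, a higher number a weaker inhibitor. The three numbers lie close to one another, and none of the gaps between them is larger than the usual scatter of repeated measurements.

Compound 1 and compound 2 differ in one place only: methyl in place of hydrogen on a saturated chain carbon, three bonds along the chain from a sulfur. This change gave a 1.4-fold lower number from compound 1 to compound 2 (0.15 log units; within the scatter), a step too small to be read as a real gain.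

Compound 4, `CCCCCCCCCCCCCCCSC[C@H](NC(C)=O)C(=O)CCl`, has not yet been measured in this assay. It is made from compound 3 by methyl in place of hydrogen on a saturated chain carbon, ten or more bonds along the chain from a sulfur. Compound 3 and compound 1 share the same kind of core, but the difference between the two cores is not broken down here. The change from compound 3 to compound 4 is the same kind of change as that from compound 1 to compound 2, though not the same: the new methyl does not sit at the same place along the chain in the two pairs, as the two descriptions of the differences show.

Because the earlier step of a 1.4-fold lower number from compound 1 to compound 2 (0.15 log units; within the scatter) stayed within the scatter, and because compound 3 gives 8800 nM, the expected step from compound 3 to compound 4 in this assay is a 1.2-fold lower number from compound 3 to compound 4 (0.07 log units; within the scatter), again an essentially flat one. Compound 4 is therefore estimated to give about 7500 nM in this assay, most likely between 3500 nM and 16000 nM.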

Compound 4, half-maximal inhibitory concentration: 8600 nM
The estimate for compound 4 lay 1.1-fold (0.06 log units) below the measured number; low and high end bracket the measured number.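

In this assay, the methyl added far out on the long chain gave a 1.0-fold lower number from compound 3 to compound 4 (0.01 log units; within the scatter) and so left the number essentially unchanged. Set beside the earlier step, the same change behaves alike on the two cores, with no difference that can be told from ordinary measurement noise: the same change on two cores in this assay, a 1.4-fold lower number (0.15 log units; within the scatter) from compound 1 to compound 2 and a 1.0-fold lower number (0.01 log units; within the scatter) from compound 3 to compound 4, 1.4-fold (0.14 log units) apart, within the scatter of two such steps. This shows that, on these two cores, adding one methyl to the end of a saturated chain on the sulfur gives no step beyond the scatter, whether the chain is short or long, but it does not show that the change would stay flat on any other core, and two steps this small cannot reveal a weak effect hidden in the noise.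

As far as these compounds go, all four compounds carry a plain saturated chain on the sulfur, so it remains open whether a chain of middling length, a branched chain, a benzyl group, or a chain ending in an amine or a carboxylic acid would move the number beyond the scatter. From the compounds shown here alone, it also remains open whether this flat behaviour would hold in any test other than this assay.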